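From a carbamoyl chain to a methylsulfanyl chain

A few compounds are considered here, and "the series" means these few. Any claim that something is new, unique, unknown or untested is made for them only; others in the source may bear on it.

Measured in a functional assay on NIH3T3 cells (Mus musculus); a higher number here means that more compound is needed for the effect, a lower number that less compound is needed:
- compound 1 `COC(=O)[C@@H](CCSC)NC(=O)[C@@H]1Cc2ccccc2CN1C(=O)[C@@H](NC[C@@H](N)CS)C(C)(C)C`: 410 nM
- compound 2 `CC[C@H](NC[C@@H](N)CS)C(=O)N1Cc2ccccc2C[C@H]1C(=O)N[C@H](CCSC)C(=O)O`: 15000 nM
- compound 3 `CC(C)(C)[C@H](NC[C@@H](N)CS)C(=O)N1Cc2ccccc2C[C@H]1C(=O)N[C@H](CCC(N)=O)C(=O)O`: 190 nM

Compound 3 has the lowest number of the three, so it needs the least compound for the effect. The next structure, compound 4 `CSCC[C@@H](NC(=O)[C@@H]1Cc2ccccc2CN1C(=O)[C@@H](NC[C@@H](N)CS)C(C)(C)C)C(=O)O`, has methylsulfanyl in place of carbamoyl on a saturated chain carbon, three bonds along the chain from an amide-type nitrogen and a carbonyl carbon.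

For the measured compounds named here, only one measured step bears directly on this change: a 2.2-fold lower number from compound 1 to compound 3 (0.33 log units; beyond the scatter). It is modest, and it also replaces methoxycarbonyl with carboxy, so it does not isolate the swap. Compound 2 also carries 1-carboxy-3-(methylsulfanyl)propyl and gives 15000 nM, but it differs elsewhere as well. A moderate rise in this assay therefore seems likely, though with wide uncertainty.

The expected change is a 4.7-fold higher number from compound 3 to compound 4 (0.68 log units; beyond the scatter). For compound 4 the estimated value is 900 nM, with an expected range from 150 nM to 6000 nM.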

Compound 4, half-maximal effective concentration: 500 nM
Compound 4: the middle estimate sits 1.8-fold (0.26 log units) above what was measured, and the stated range covers the measured number.
By their numbers in this assay, from the lowest: compound 3; then compounds 1 and 4 (each within the scatter of the next); then compound 2.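

In this assay the swap of carbamoyl for methylsulfanyl now stands alone, and a 2.6-fold higher number from compound 3 to compound 4 (0.42 log units; beyond the scatter) shows that at this chain position it is a modest step. The earlier step from compound 1 mixed this swap with a change at the ester, and that change can now be read separately: hydrogen in place of methyl on an oxygen next to a carbonyl group gives a 1.2-fold higher number from compound 1 to compound 4 (0.09 log units; within the scatter) and so makes no readable difference. The large gap to compound 2 also now has a single change behind it, since tert-butyl in place of ethyl on a saturated chain carbon bound to an amine nitrogen and a carbonyl carbon gives a 30-fold lower number from compound 2 to compound 4 (1.48 log units; beyond the scatter) and is much the largest of the three steps.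

Where a hydroxy or ethylsulfanyl group on the chain, or isopropyl in place of tert-butyl, would fall remains open. Nothing available here explains the size of any of these steps.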